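The compounds below may be only part of what the source reports. "The series", "measured", "known", "first", "only" and "open" are said of these compounds alone.

Measured so far in a functional assay on the whole organism (strain Holtzman) with Rattus norvegicus as the target; on this read-out lower numbers stand for an effect already at smaller amounts and higher numbers for an effect only at larger amounts of compound:
compound 1 `Cc1nn(C)c2c1C(c1ccccc1Cl)=NCC(=O)N2` — 2.5 mg/kg
compound 2 `CCCCc1nn(C)c2c1C(c1ccccc1Cl)=NCC(=O)N2` — > 40 mg/kg, a limit of the assay, not a number

Among the measured compounds shown here, compound 1 holds the only number on this read-out in this assay. Compound 2 sits at the limit (the limit of > 40 mg/kg in this assay, at which 1 of the 2 values shown sits). Compound 3 `CCCn1nc(C)c2c1NC(=O)CN=C2c1ccccc1Cl` differs from compound 1 in that (ethyl in place of hydrogen on a saturated chain carbon bound to an aromatic nitrogen). For the measured compounds named here, the single measured step, an at least 16-fold higher number from compound 1 to compound 2 (1.20 log units; beyond the scatter), concerns a different place on the shared core, yet it is the only evidence on lengthening an alkyl chain there, so a rise of moderate size is expected, a 4.0-fold higher number from compound 1 to compound 3 (0.60 log units; beyond the scatter). Compound 3 is estimated at 10 mg/kg, with a range from 3 mg/kg to 40 mg/kg.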

Compound 3, minimum effective dose: 40 mg/kg
Beside the measured number, compound 3's estimate is 4.0-fold (0.60 log units) below it; low and high end bracket the measured number.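

In this assay, ethyl in place of hydrogen on a saturated chain carbon bound to an aromatic nitrogen gives a 16-fold higher number from compound 1 to compound 3 (1.20 log units; beyond the scatter), so the second alkyl position shown also loses effect at low dose on lengthening. The earlier step, an at least 16-fold higher number from compound 1 to compound 2 (1.20 log units; beyond the scatter), runs the same way, and neither compound goes against this. Compound 2 is only a limit, so the sizes of the two steps cannot be ranked: the limit of > 40 mg/kg in this assay, at which 1 of the 3 values shown sits.

Open, as far as these compounds go, is how an ethyl or isopropyl group reads at this place. Also open, from the compounds shown here alone, is whether an amine or carboxylic acid carried on the propyl chain brings the number back down.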